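The compounds below may be only part of what the source reports. "The series", "measured", "known", "first", "only" and "open" are said of these compounds alone.

Working notes on the series. In a functional assay on HCT-116 cells (Homo sapiens) for inhibition (a lower number here means a stronger inhibitor, a higher number a weaker inhibitor), compound 3 `COc1ccc(/C=C/c2ccc3ccccc3c2)cc1N` gives 1820 nM, and compound 1 `COCCOc1cc(/C=C\c2ccc3ccccc3c2)ccc1OC` gives 2990 nM; these two values lie within the scatter of each other. Compound 2 `COc1ccc(/C=C\c2ccc3ccccc3c2)cc1[N+](=O)[O-]` reads > 20000 nM, which is a limit of the assay and not a number.

Compound 4 `COc1ccc(/C=C\c2ccc3ccccc3c2)cc1N` is the next compound to be measured in this assay. The change is the two compounds have the same atoms and bonds and differ only in configuration as drawn: 1 of 1 stereo elements differ; a double bond is drawn E in compound 3 and Z in compound 4. Nothing leaves and nothing enters.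

Among the measured compounds shown here, only one measured step exists, an at least 6.6-fold higher number from compound 1 to compound 2 (0.82 log units; beyond the scatter). It lies beyond the scatter and ends at a limit, but it concerns a substituent exchange with the double bond drawn Z throughout, so it bears on compound 4 only indirectly. For the measured compounds named here, it shows that this assay responds to the group at that place when the double bond is drawn Z. No measured pair isolates the double bond configuration, so the size of this step is a judgement and the range stays wide. Compound 3, at 1820 nM, already falls within the scatter of the Z compound 1, and a lower number is expected once its amine is carried on the Z double bond.

The expected change is a 9.1-fold lower number from compound 3 to compound 4 (0.96 log units; beyond the scatter), a step beyond the scatter. For compound 4 the estimated value is 200 nM, with an expected range of 20 nM to 2000 nM.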

Compound 4, half-maximal inhibitory concentration: 360 nM
Compound 4: middle estimate off by 1.8-fold (0.26 log units), on the low side, within the range that was stated.
By their numbers in this assay, from the lowest: compound 4; then compounds 3 and 1 (each within the scatter of the next). At a limit, above all of these: compound 2.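

Among the compounds shown here, the configuration of the double bond matters on its own in this assay, where the first pair that isolates it gives a 5.1-fold lower number from compound 3 to compound 4 (0.70 log units; beyond the scatter), with the lower number on the Z side: the fact that compounds 3 and 4 differ only in the configuration as drawn. With the double bond drawn Z, the amino group also separates from both other groups at this place, with amino in place of 2-methoxyethoxy giving an 8.3-fold lower number from compound 1 to compound 4 (0.92 log units; beyond the scatter) and amino in place of nitro giving an at least 55-fold lower number from compound 2 to compound 4 (1.74 log units; beyond the scatter). Compound 2 reads > 20000 nM, which is a limit of the assay and not a number, so the step from it gives a bound and not a size: the limit of > 20000 nM in this assay, at which 1 of the 4 values shown sits.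

The compounds shown leave open how a hydroxyl, a methylamino or an acetamide group at this place would compare with amino on the Z double bond. The only configuration pair shown carries amino, so it remains open whether a similar step between E and Z would appear with nitro or 2-methoxyethoxy at this place.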